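From 3-methoxyphenyl to 4-methoxyphenyl in compound 1

The source may report more compounds than this note shows. Statements on the series, on what has been measured and on what is new or still open speak of the compounds shown alone.

Measured in a functional assay on HT-29 cells (Homo sapiens) for antiproliferative activity, read by MTT assay, with a stated time of 48 h; on this read-out higher numbers stand for weaker inhibition of growth and lower numbers for stronger inhibition of growth:
compound 1 `CCOC(=O)N1N=C(c2cccc(OC)c2)CC1c1cc(OC)c(OC)c(OC)c1`: 7860 nM
compound 2 `CCCOC(=O)N1N=C(c2cccc(OC)c2)CC1c1cc(OC)c(OC)c(OC)c1`: > 10000 nM (a limit)
compound 3 `COc1cccc(C2=NN(C(=O)OCc3ccccc3)C(c3cc(OC)c(OC)c(OC)c3)C2)c1`: > 10000 nM (a limit)

Among these three, compound 1 alone has a true number, 7860 nM. Compound 2 and compound 3 each reach only a limit, so compound 1 cannot be placed exactly against either of them.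

The next compound is compound 4 `CCOC(=O)N1N=C(c2ccc(OC)cc2)CC1c1cc(OC)c(OC)c(OC)c1`, and the change is 4-methoxyphenyl in place of 3-methoxyphenyl on a carbon with a double bond to nitrogen. In words, it is 4-methoxyphenyl in place of 3-methoxyphenyl on a carbon with a double bond to nitrogen.

Two measured steps start from compound 1: an at least 1.2-fold higher number from compound 1 to compound 2 (0.10 log units; that floor lies within the scatter) and an at least 1.2-fold higher number from compound 1 to compound 3 (0.10 log units; that floor lies within the scatter). Both alter the chain on the oxygen next to the carbonyl group and leave the methoxyphenyl group untouched, so neither bears directly on this change. They give no direction and no size for it, and no step beyond the scatter is expected in this assay. The estimated step is a 1.0-fold higher number from compound 1 to compound 4 (0.01 log units; within the scatter).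

A result reported only as a limit is also a real possibility for compound 4 because of the limit of > 10000 nM in this assay, at which 2 of the 3 values shown sit.

Compound 4 is expected at 8000 nM, with an estimated range from 3000 nM to 20000 nM.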

Compound 4, concentration for 50% growth inhibition: 6730 nM
Compound 4: the middle estimate sits 1.2-fold (0.08 log units) above what was measured; the range from low to high includes it.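

In this assay, placing 4-methoxyphenyl instead of 3-methoxyphenyl on the carbon with a double bond to nitrogen gives a 1.2-fold lower number from compound 1 to compound 4 (0.07 log units; within the scatter), so exchanging these two methoxyphenyl groups leaves no difference that can be told apart from the scatter of the measurements. Going by these compounds alone, the earlier steps altered only the chain on the oxygen next to the carbonyl group, whereas this one is the first to touch the methoxyphenyl position and the first with a true number at both ends, which makes its size readable. Compound 2 and compound 3 remain limits and not numbers, so the compounds with true values are confined to the ethoxycarbonyl pair: the limit of > 10000 nM in this assay, at which 2 of the 4 values shown sit.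

What the compounds shown leave open is whether this position responds to anything other than a methoxyphenyl group, such as 2-methoxyphenyl, 4-hydroxyphenyl or 4-chlorophenyl, since only two arrangements of the same atoms are compared here. As far as these compounds go, it also remains open whether 4-methoxyphenyl would give a true number alongside the propyl or benzyl chains on the oxygen next to the carbonyl group, or alongside a shorter methyl chain there.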